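Trimming the cinnamamide aryl group on a quinazoline core

The source may report more compounds than this note shows. Statements on the series, on what has been measured and on what is new or still open speak of the compounds shown alone.

For the measured compounds named here, compound 1 `COc1cc(/C=C/C(=O)Nc2cc3c(Nc4ccc(F)c(Cl)c4)ncnc3cc2O[C@H]2CCOC2)cc(OC)c1OC` is the only member of this set with a reported number. In a functional assay on HeLa cells (Homo sapiens) for cytotoxicity, read by MTT assay, with a stated time of 72 h (on this read-out higher numbers stand for weaker inhibition and lower numbers for stronger inhibition), compound 1 gives 24500 nM, a weak result that nonetheless serves as the sole anchor here. Compound 2 `COc1ccc(/C=C/C(=O)Nc2cc3c(Nc4ccc(F)c(Cl)c4)ncnc3cc2OC)c(OC)c1`, which shares the core but carries a methoxy ether in place of the oxolane ether, has in this assay only the entry "not determined" (no result reported), so it offers no comparison.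

Compound 3 `COc1ccc(/C=C/C(=O)Nc2cc3c(Nc4ccc(F)c(Cl)c4)ncnc3cc2O[C@H]2CCOC2)cc1` keeps the oxolane ether and the anilino group of compound 1 and changes only the aryl ring on the cinnamamide: 4-methoxyphenyl in place of 3,4,5-trimethoxyphenyl on a double-bonded chain carbon bound to a double-bonded chain carbon. Going by the values given here, no measured pair in this set isolates such a change, so the expectation rests on compound 1 alone. The step of a 1.2-fold lower number from compound 1 to compound 3 (0.09 log units; within the scatter) is estimated to stay within the usual scatter, with no clear direction. Compound 3 is therefore expected to give 20000 nM, with a range from 6000 nM to 60000 nM.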

Compound 3, half-maximal inhibitory concentration: 34600 nM
Compound 3: middle estimate off by 1.7-fold (0.24 log units), on the low side; measured number inside the range.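

In this assay, for the compounds shown here, 4-methoxyphenyl in place of 3,4,5-trimethoxyphenyl on a double-bonded chain carbon bound to a double-bonded chain carbon gives a 1.4-fold higher number from compound 1 to compound 3 (0.15 log units; within the scatter), the first readable step at this position. The aryl group can therefore go from 12 heavy atoms and 3 hydrogen-bond acceptors to 8 heavy atoms and 1 hydrogen-bond acceptor while the read-out stays within the scatter. No measurement at hand explains this result.

As far as these compounds go, what a phenyl group bearing an amine or a carboxylic acid would do at this place remains open, as does whether any aryl group here can move the number beyond the scatter. From the compounds shown here alone, whether the oxolane ether itself matters to the read-out also stays open.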